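This account rests on a few compounds, and the source may have more. Where it says the series, first, only, none or still open, it means among the compounds named here.

Working notes on the series in a functional assay on COLO 205 cells (Homo sapiens) for inhibition, read by sulforhodamine B assay; a higher number here means a weaker inhibitor of growth, a lower number a stronger inhibitor of growth.

Three compounds are measured. Compound 1 `c1ccc(-c2ccc(-c3ccc(-c4nc5ccccc5[nH]4)cc3)cc2)cc1` gives 100000 nM. Compound 3 `COc1ccc(-c2ccc(-c3ccc(-c4nc5ccccc5[nH]4)cc3)cc2)cc1OC` gives 41200 nM. Compound 2 `COc1ccc(-c2ccc(-c3ccc(-c4nc5cc(C)ccc5[nH]4)cc3)cc2)cc1OC` gives 2320 nM, the lowest of the three numbers, with every step to the others beyond the scatter.

Two single changes connect them. From compound 3 to compound 1 the change is phenyl in place of 3,4-dimethoxyphenyl on an aromatic carbon, and the step is a 2.4-fold higher number from compound 3 to compound 1 (0.39 log units; beyond the scatter). From compound 3 to compound 2 the change is methyl in place of hydrogen on an aromatic carbon; read in the other direction, an 18-fold higher number from compound 2 to compound 3 (1.25 log units; beyond the scatter). The second change carries far more weight than the first within these three.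

Compound 4 `Cc1ccc2[nH]c(-c3ccc(-c4ccc(-c5ccccc5)cc4)cc3)nc2c1` awaits measurement. It differs from compound 2 by phenyl in place of 3,4-dimethoxyphenyl on an aromatic carbon, which is the same change as that from compound 3 to compound 1, made at the same place. The two cores differ only in that the core of compound 2 carries methyl where the core of compound 3 carries hydrogen.

Going by the values given here, for compound 4 the expected step from compound 2 is a 2.4-fold higher number from compound 2 to compound 4 (0.38 log units; beyond the scatter), set beside the one measured instance, because the same change on the other core gave a 2.4-fold higher number from compound 3 to compound 1 (0.39 log units; beyond the scatter). That single instance is the only basis, so the range is kept wide. Compound 4 is accordingly estimated at 5600 nM, expected to fall between 2500 nM and 20000 nM.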

Compound 4, concentration for 50% growth inhibition: 2560 nM
Compound 4: middle estimate off by 2.2-fold (0.34 log units), on the high side; low and high end bracket the measured number.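

In this assay, phenyl in place of 3,4-dimethoxyphenyl gives a 1.1-fold higher number from compound 2 to compound 4 (0.04 log units; within the scatter), and the step on this core cannot be told apart from the step on the other core: the same change on two cores in this assay, a 2.4-fold higher number (0.39 log units; beyond the scatter) from compound 3 to compound 1 and a 1.1-fold higher number (0.04 log units; within the scatter) from compound 2 to compound 4, 2.2-fold (0.34 log units) apart, within the scatter of two such steps. Methyl in place of hydrogen on an aromatic carbon gives a 39-fold lower number from compound 1 to compound 4 (1.59 log units; beyond the scatter), and this large step also carries from one terminal aryl group to the other: the same change on two cores in this assay, an 18-fold higher number (1.25 log units; beyond the scatter) from compound 2 to compound 3 and a 39-fold higher number (1.59 log units; beyond the scatter) from compound 4 to compound 1, 2.2-fold (0.34 log units) apart, within the scatter of two such steps. Both changes therefore behave consistently across the four compounds, but this rests on a single pair of steps for each change, so it does not show that either step would hold on a further core, and it does not settle whether the exchange of 3,4-dimethoxyphenyl for phenyl has any real effect, as that step is beyond the scatter on one core and within it on the other.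

The compounds shown leave open how an ethyl group, a chlorine atom or an amine would read in place of the methyl on the shared core. They also leave open how a single methoxy group or a carboxylic acid on the terminal phenyl would read, and whether either would carry between the two cores in the same way.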